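This account rests on a few compounds, and the source may have more. Where it says the series, first, only, none or still open, it means among the compounds named here.

In a functional assay on NCI-H460 cells (Homo sapiens) for antiproliferative activity, read by sulforhodamine B assay, with a stated time of 72 h (a higher number here means a weaker inhibitor, a lower number a stronger inhibitor), two compounds have numbers so far:
compound 1 (`CCN1C(=O)CS/C1=N/Nc1nncc2ccccc12`): 28 nM
compound 2 (`O=S(=O)(Nc1ncccn1)c1ccc(Nc2nncc3ccccc23)cc1`): 33 nM

Compound 2 stands level with compound 1, since their two numbers lie within the scatter of each other. Compound 3 (`NS(=O)(=O)c1ccc(Nc2nncc3ccccc23)cc1`) has hydrogen in place of pyrimidin-2-yl on a sulfonamide nitrogen. Within the data shown here, no measured pair shows this change, so the data give no direct guide to its size in this assay here. A moderate move toward a weaker inhibitor is expected, the estimated step being a 1.8-fold higher number from compound 2 to compound 3 (0.26 log units; within the scatter) in size. The estimate for compound 3 is 60 nM with an expected range of 15 nM to 240 nM around it.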

Compound 3, half-maximal inhibitory concentration: 17 nM
Estimate against measurement, compound 3: 3.5-fold (0.55 log units) above; measured number inside the range.
By their numbers in this assay, from the lowest: compounds 3, 1 and 2 (each within the scatter of the next).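

On the sulfonamide nitrogen, hydrogen in place of pyrimidin-2-yl gives a 1.9-fold lower number from compound 2 to compound 3 (0.29 log units; within the scatter) in this assay. This single pair therefore shows that removing the six-membered aromatic ring, with its 6 heavy atoms, leaves compound 3 level with compound 2. Nothing at hand explains this result. The compounds shown leave open whether a methyl or acetyl group on that nitrogen would also stay level with hydrogen and pyrimidin-2-yl. They also leave open how a carboxylic acid in place of the whole sulfonamide would read.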